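Replacing 3,5-dichlorophenyl with 2-phenylethenyl on a shared core

The source may report more compounds than this note shows. Statements on the series, on what has been measured and on what is new or still open speak of the compounds shown alone.

Four compounds share one core and differ only in the group on a carbonyl carbon. In a functional assay on C8166 cells (Homo sapiens) for cytotoxicity, read by MTT assay (a lower number here means that less compound is tolerated, a higher number that more compound is tolerated), compound 1 (`Cc1cc(S(N)(=O)=O)ccc1NC(=O)COc1ccc(Cl)cc1NC(=O)c1cccc(F)c1`) gives 243000 nM, compound 2 (`Cc1cc(S(N)(=O)=O)ccc1NC(=O)COc1ccc(Cl)cc1NC(=O)c1ccccc1[N+](=O)[O-]`) gives 54800 nM, and compound 3 (`Cc1cc(S(N)(=O)=O)ccc1NC(=O)COc1ccc(Cl)cc1NC(=O)c1cc(Cl)cc(Cl)c1`) gives 72400 nM. Compound 3 thus stands level with compound 2 and clearly under compound 1. The two close values are separated by a 1.3-fold higher number from compound 2 to compound 3 (0.12 log units; within the scatter), whereas the gap to the highest value is a 3.4-fold lower number from compound 1 to compound 3 (0.53 log units; beyond the scatter).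

Compound 4 (`Cc1cc(S(N)(=O)=O)ccc1NC(=O)COc1ccc(Cl)cc1NC(=O)/C=C/c1ccccc1`) makes a single change to compound 3: 2-phenylethenyl in place of 3,5-dichlorophenyl on a carbonyl carbon. For the measured compounds named here, all the measured steps swap the group at this same place, so they are the best guide, although none of them involves 2-phenylethenyl. The widest is only modest, at a 4.4-fold lower number from compound 1 to compound 2 (0.65 log units; beyond the scatter). On these data alone, on that evidence, no step beyond the scatter is expected in this assay, and the direction remains open. The estimated step is a 1.2-fold higher number from compound 3 to compound 4 (0.09 log units; within the scatter). For compound 4 the expected value is 90000 nM, with an estimated range of 35000 nM to 230000 nM.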

Compound 4, half-maximal cytotoxic concentration: 163000 nM
Compound 4: the middle estimate sits 1.8-fold (0.26 log units) below what was measured; measured number inside the range.
By their numbers in this assay, from the lowest: compounds 2 and 3 (each within the scatter of the next); then compounds 4 and 1 (each within the scatter of the next).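

In this assay, for the compounds shown here, 2-phenylethenyl is the first group at this carbonyl carbon with a double bond outside the aromatic ring, and this change gives a 2.3-fold higher number from compound 3 to compound 4 (0.35 log units; beyond the scatter) and a 3.0-fold higher number from compound 2 to compound 4 (0.47 log units; beyond the scatter), whereas a 1.5-fold lower number from compound 1 to compound 4 (0.17 log units; within the scatter) leaves compound 4 and compound 1 indistinguishable. The upper level of this small series is therefore reached by two different groups, 3-fluorophenyl and 2-phenylethenyl, so it does not depend on an aromatic ring sitting directly on the carbonyl carbon. No measured evidence here explains these differences.

On these data alone, it remains open whether the double bond itself matters, which 2-phenylethyl, the same group with that bond saturated, could test. How an amine or a carboxylic acid on the aromatic ring of 2-phenylethenyl would shift the number is also unknown.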